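The compounds below may be only part of what the source reports. "The series", "measured", "known", "first", "only" and "open" are said of these compounds alone.

Of the compounds shown here, three of one shared core have been measured. Compound 1 `CCc1cccc(NC(=O)CN2CCN(c3ccccn3)CC2)c1` gives 1310 nM in a functional assay on cells for antagonist activity at D(4) dopamine receptor (Homo sapiens), read by TR-FRET and cAMP accumulation, with a stated time of 30 min; on this read-out higher numbers stand for weaker inhibition and lower numbers for stronger inhibition. Compound 2 `O=C(CN1CCN(c2ccccn2)CC1)Nc1cncnc1` reaches only > 100000 nM in this assay, which is a limit of the assay and not a number. Compound 3 `Cc1cccc(NC(=O)CN2CCN(c3ccc(Cl)cn3)CC2)c1` gives 4700 nM in this assay and so holds the highest of the two numbers; the nearest, compound 1, stands lower by a gap beyond the scatter. Compound 4 `Cc1cccc(NC(=O)CN2CCN(c3ccccn3)CC2)c1` differs from compound 3 by hydrogen in place of chloro on an aromatic carbon. The only measured step, an at least 76-fold higher number from compound 1 to compound 2 (1.88 log units; beyond the scatter), concerns the substituent on the amide-type nitrogen and does not touch the pyridin-2-yl group, so no shown step bears directly on this change. The analyst therefore expects a modest downward step at most, a 2.1-fold lower number from compound 3 to compound 4 (0.33 log units; beyond the scatter). Compound 4 is estimated at 2200 nM, with a range from 700 nM to 7000 nM.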

Compound 4, half-maximal inhibitory concentration: 82.7 nM
For compound 4 the middle estimate is 27-fold (1.42 log units) above the measured one, and the stated range ends above it.
By their numbers in this assay, from the lowest: compound 4; then compound 1; then compound 3. At a limit, above all of these: compound 2.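

Among these compounds, on the pyridin-2-yl group, chloro on this aromatic carbon, two atoms from the ring nitrogen, proves far from neutral, a large effect that no earlier compound showed: a 57-fold lower number from compound 3 to compound 4 (1.75 log units; beyond the scatter). The chain on the amide-side phenyl ring also matters, since 3-methylphenyl outperforms 3-ethylphenyl in a large step: a 16-fold lower number from compound 1 to compound 4 (1.20 log units; beyond the scatter). Compound 2 stands at a limit, so an at least 1200-fold lower number from compound 2 to compound 4 (3.08 log units; beyond the scatter) is a bound and not an exact size.

Nothing shown gives a cause for these steps. Still open, on these data alone, is how fluoro or methoxy on that pyridine carbon would read, and whether a propyl chain would continue the trend from methyl to ethyl.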